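Working notes: from compound 3 to compound 4

The source may hold more compounds than are shown below. What is called first, only, known or untested is meant among the compounds shown, and "the series" means these compounds.

Measured in an ADME assay on cells (Peritoneal macrophage, Mus musculus) for cytotoxicity, read by CCK-8 assay, with a stated time of 24 h; a lower number here means that less compound is tolerated, a higher number that more compound is tolerated:
- compound 1 `COc1ccc(S(=O)(=O)N(CC(N)=O)c2ccc(N(CC(N)=O)S(=O)(=O)c3ccc([S+]([O-])CCN=C=S)cc3)c3ccccc23)cc1`: > 10000 nM (a limit)
- compound 2 `COc1ccc(S(=O)(=O)N(CC(N)=O)c2ccc(N(CC(N)=O)S(=O)(=O)c3ccc([S+]([O-])CCCCCN=C=S)cc3)c3ccccc23)cc1`: > 10000 nM (a limit)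
- compound 3 `COc1ccc(S(=O)(=O)N(CC(N)=O)c2ccc(N(CC(N)=O)S(=O)(=O)c3ccc([S+]([O-])CCOCCN=C=S)cc3)c3ccccc23)cc1`: > 10000 nM (a limit)

Compound 3 has no numerical value, only the limit > 10000 nM. The series as a whole shows (the limit of > 10000 nM in this assay, at which 3 of the 3 values shown sit).

Compound 4 `COc1ccc(S(=O)(=O)N(CC(N)=O)c2ccc(N(CC(N)=O)S(=O)(=O)c3ccc([S+]([O-])CCOCCOCCN=C=S)cc3)c3ccccc23)cc1` differs from compound 3 by a group of 6 heavy atoms (3 carbon, 1 nitrogen, 1 oxygen, 1 sulfur; no ring) in place of a group of 3 heavy atoms (1 carbon, 1 nitrogen, 1 sulfur; no ring), on a saturated chain carbon, two bonds along the chain from an oxygen on a saturated carbon. The closest measured precedent is a step that the two limits leave unreadable from compound 1 to compound 3, which has the same group of 6 heavy atoms entering in place of the group of 3 heavy atoms. Also relevant are a step that the two limits leave unreadable from compound 1 to compound 2 and a step that the two limits leave unreadable from compound 2 to compound 3. None of these steps has a readable size, so they give no direction. They do show that no measured change in this chain has brought a value inside the limit.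

No step beyond the scatter is therefore expected in this assay, and the estimated change is a step that the limit leaves unreadable from compound 3 to compound 4. A further limit is the most likely report. The estimate for compound 4 is 15000 nM, with an expected range of 8000 nM to 40000 nM.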

Compound 4, half-maximal cytotoxic concentration: > 10000 nM
Compound 4: no number, only a limit; the forecaster's own chance of this, stated with the estimate: 90%; the middle value is on the limit's open side.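

In this assay compound 4 gives > 10000 nM, which is a limit, so its steps from compound 1, compound 2 and compound 3 cannot be read. The compounds shown leave open how any of these chains would rank once measured as a number, as all remain at one limit: the limit of > 10000 nM in this assay, at which 4 of the 4 values shown sit.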